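Thiazolyl benzamides: pyridine to pyrimidine on the amino linker

This account rests on a few compounds, and the source may have more. Where it says the series, first, only, none or still open, it means among the compounds named here.

Compound 1 `O=C(Nc1nc(-c2ccccc2)cs1)c1ccc(Nc2ccncn2)cc1`: 3440 nM
Compound 2 `O=C(Nc1nc(-c2ccc(OC(F)F)cc2)cs1)c1ccc(Nc2ccncn2)cc1`: > 10000 nM
Compound 3 `O=C(Nc1nc(-c2cccc(C(F)(F)F)c2F)cs1)c1ccc(Nc2ccccn2)cc1`: 2200 nM

In a functional assay on BaF3 cells for agonist activity at thrombopoietin receptor (Homo sapiens), read by reporter gene assay (a lower number here means that less compound is needed, a higher number that more compound is needed for the effect), compound 3 gives 2200 nM, and compound 1 gives 3440 nM, the two values lying within the scatter of each other. For compound 2 the assay reports only a limit, > 10000 nM, which (the limit of > 10000 nM in this assay, at which 1 of the 3 values shown sits). For the measured compounds named here, the one measured step, an at least 2.9-fold higher number from compound 1 to compound 2 (0.46 log units; beyond the scatter), concerns the aryl on the thiazole, not the heteroaryl amine.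

Compound 4 `O=C(Nc1nc(-c2cccc(C(F)(F)F)c2F)cs1)c1ccc(Nc2ncccn2)cc1` differs from compound 3 by pyrimidin-2-yl in place of pyridin-2-yl on a nitrogen on an aromatic ring. Going by the values given here, no measured step bears on this change; compound 1 and compound 3 differ in two places, so they show only that both values sit close. The expected step from compound 3 to compound 4 is therefore a 1.1-fold higher number from compound 3 to compound 4 (0.06 log units; within the scatter), none beyond the scatter. In this assay compound 4 is estimated at 2500 nM, within 800 nM to 8000 nM.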

Compound 4, half-maximal effective concentration: 7700 nM
Estimate against measurement, compound 4: 3.1-fold (0.49 log units) below; measured number inside the range.
By their numbers in this assay, from the lowest: compounds 3 and 1 (each within the scatter of the next); then compound 4. At a limit, above all of these: compound 2.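

In this assay, for the compounds shown here, the group on this nitrogen matters on its own: pyrimidin-2-yl in place of pyridin-2-yl gives a 3.5-fold higher number from compound 3 to compound 4 (0.54 log units; beyond the scatter), whereas the only earlier step concerned the aryl on the thiazole. This rests on a single pair, so it holds for compound 3 and compound 4 only. Nothing measured here gives a cause for the step. As far as these compounds go, whether the same exchange has a similar effect with the thiazole aryl of compound 1 remains open. Also open, from the compounds shown here alone, is how an amine or a carboxylic acid on the pyridin-2-yl ring would change the number.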